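The source may hold more compounds than are shown below. What is called first, only, known or untested is meant among the compounds shown, and "the series" means these compounds.

Two compounds share one core and differ only in the group on the five-membered ring. Compound 1 `CS(=O)(=O)c1cnc(C(=O)CCc2ccc(-c3ccccc3)cc2)o1` carries a methylsulfonyl there, and in an assay for inhibition of Fatty-acid amide hydrolase 1 (Rattus norvegicus) (a lower number here means a stronger inhibitor, a higher number a weaker inhibitor), compound 1 gives 1.2 nM. Compound 2 `O=C(CCc1ccc(-c2ccccc2)cc1)c1ncc(C(=O)C(F)(F)F)o1` carries a (trifluoromethyl)carbonyl in its place, and in this assay compound 2 gives 8 nM. Going by the values given here, the single measured step, a 6.7-fold higher number from compound 1 to compound 2 (0.82 log units; beyond the scatter), is a modest weakening, so compound 2 stands highest of the two numbers, the weaker inhibitor of the pair. Compound 3 `O=C(CCc1ccc(-c2ccccc2)cc1)c1ncc(-c2cccnc2)o1` is not yet measured; it differs from compound 2 by pyridin-3-yl in place of (trifluoromethyl)carbonyl on an aromatic carbon. Among the compounds with values here, no measured step exchanges the (trifluoromethyl)carbonyl for a ring, so the one known step only sets a scale of change at this position. For compound 3 the expected step is a 1.6-fold lower number from compound 2 to compound 3 (0.20 log units; within the scatter), a return toward stronger inhibition. The estimate for compound 3 in this assay is 5 nM, expected between 1.5 nM and 15 nM.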

Compound 3, inhibition constant: 1.1 nM
The estimate for compound 3 lay 4.5-fold (0.66 log units) above the measured number, and the stated range ends above it.
By their numbers in this assay, from the lowest: compounds 3 and 1 (each within the scatter of the next); then compound 2.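

A ring can sit at this position: the change to pyridin-3-yl gives a 7.3-fold lower number from compound 2 to compound 3 (0.86 log units; beyond the scatter) in this assay, so a group with no carbonyl or sulfonyl does well on this carbon next to the ring oxygen. Against the methylsulfonyl, the same ring gives a 1.1-fold lower number from compound 1 to compound 3 (0.04 log units; within the scatter), which means two very different groups cannot be told apart here, while the (trifluoromethyl)carbonyl stands apart from both. No measurement offered here explains this ranking.

The compounds shown leave open whether the nitrogen of the pyridin-3-yl matters, which a plain phenyl ring on this carbon would test, or whether its place in the ring counts, as a pyridin-2-yl would show. They also leave open how an amine or a carboxylic acid would fare at this position.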